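A few compounds are considered here, and "the series" means these few. Any claim that something is new, unique, unknown or untested is made for them only; others in the source may bear on it.

Measured so far in an assay on HEK293 cells for antagonist activity at Toll-like receptor 9 (Homo sapiens), read by spectrophotometry; on this read-out lower numbers stand for stronger inhibition and higher numbers for weaker inhibition:

Compound 1 `CCN1CCN(CCCn2cnc3c(N4CCN(CC)CC4)nc(NCc4ccccc4)nc32)CC1` — 140 nM
Compound 2 `CCN1CCN(CCCn2cnc3c(N4CCN(C(=O)C5CCCC5)CC4)nc(NCc4ccc(N(CC)CC)cc4)nc32)CC1` — 8800 nM
Compound 3 `COc1ccc(CNc2nc(N3CCN(C4CCCC4)CC3)c3ncn(CCCN4CCCC4)c3n2)cc1` — 240 nM

Compound 1 gives the smallest of the three numbers in this assay. Its gap to compound 3 is within the scatter, so the two cannot be ranked against each other. Its gap to compound 2 is beyond the scatter; compound 2 carries a cyclopentanecarbonyl on one of its piperazines, and it gives by far the highest number of the set.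

The next compound, compound 4 `CCN1CCN(CCCn2cnc3c(N4CCN(CC)CC4)nc(NC(=O)c4ccccc4)nc32)CC1`, keeps the shared core of compound 1 and changes one position: benzoyl in place of benzyl on a nitrogen on an aromatic ring. The amine hydrogen remains, but the nitrogen now carries a carbonyl rather than a methylene.

Within the data shown here, no measured pair in the set shows this change directly. The only other amide in the set, compound 2, has its amide at a different place, so it is at best a loose guide. The change from benzylamino to benzamido is nonetheless expected to weaken inhibition, as a step of an 8.6-fold higher number from compound 1 to compound 4 (0.93 log units; beyond the scatter) that is expected to lie beyond the scatter. For compound 4 the estimate is 1200 nM, with a range from 250 nM to 6000 nM.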

Compound 4, half-maximal inhibitory concentration: 340 nM
Estimate against measurement, compound 4: 3.5-fold (0.55 log units) above; measured number inside the range.
By their numbers in this assay, from the lowest: compounds 1, 3 and 4 (each within the scatter of the next, the first and the last beyond it); then compound 2.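

In this assay, among these compounds, benzoyl in place of benzyl on a nitrogen on an aromatic ring gives a 2.4-fold higher number from compound 1 to compound 4 (0.39 log units; beyond the scatter), a modest step that still lies beyond the scatter and is the first direct reading at this position, since compounds 1, 2 and 3 all carry a benzyl-type group on this nitrogen. The nitrogen therefore accepts a carbonyl in place of the methylene at a limited cost: the amine hydrogen stays, the benzoyl adds one oxygen and one hydrogen-bond acceptor, and compound 4 still gives 340 nM, so inhibition weakens without being lost. No measurement at hand accounts for the size of this step, and it rests on this single pair.

Still open, going by these compounds, is how other links on this nitrogen would read, such as a phenylsulfonyl, a phenylacetyl with its longer chain, or a phenylcarbamoyl forming a urea. Also open, on these data alone, is whether the same change costs a similar amount with the methoxy-substituted ring and the cyclopentyl and pyrrolidine groups of compound 3.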